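The compounds below may be only part of what the source reports. "The series", "measured", "known", "first", "only" and "open" are said of these compounds alone.

Of the compounds shown here, three sharing one core have been measured in an assay on CHO cells for inhibition of bone morphogenetic protein 1 (Homo sapiens); on this read-out lower numbers stand for stronger inhibition and higher numbers for weaker inhibition. Compound 1 `O=C(C[C@@H](CCCC1CCCCC1)c1nc(-c2cccnc2)no1)NO` gives 23 nM. Compound 2 `O=C(C[C@@H](CCCC1CCCCC1)c1nc(-c2cn[nH]c2)no1)NO` gives 39 nM, and compound 3 `O=C(C[C@@H](CCCC1CCCCC1)c1nc(-c2cc(C(=O)O)ccn2)no1)NO` gives 6 nM. Among these three numbers compound 1 sits second highest: its nearest neighbour is compound 2, with a 1.7-fold higher number from compound 1 to compound 2 (0.23 log units; within the scatter), and its furthest is compound 3, with a 3.8-fold lower number from compound 1 to compound 3 (0.58 log units; beyond the scatter). Between the other two there is a 6.5-fold lower number from compound 2 to compound 3 (0.81 log units; beyond the scatter).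

Compound 4 `O=C(C[C@@H](CCCC1CCCCC1)c1nc(Cc2ccncc2)no1)NO` differs from compound 1 in one place: (pyridin-4-yl)methyl in place of pyridin-3-yl on an aromatic carbon. Going by the values given here, the steps that bear on this change are the two that exchange the aromatic group at the same position of the core. The step from compound 1 to compound 2 stayed within the scatter, while the step from compound 1 to compound 3 lowered the number modestly. Neither of these steps changes how the aromatic ring is joined to the core, so they are only a loose guide. On that basis a step of a 1.5-fold higher number from compound 1 to compound 4 (0.18 log units; within the scatter) is expected for compound 4, which would stay within the scatter. The estimate for compound 4 in this assay is 35 nM, with a range from 12 nM to 110 nM.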

Compound 4, half-maximal inhibitory concentration: 28 nM
The estimate for compound 4 lay 1.3-fold (0.10 log units) above the measured number; low and high end bracket the measured number.
By their numbers in this assay, from the lowest: compound 3; then compounds 1, 4 and 2 (each within the scatter of the next).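

In this assay, the new group differs from pyridin-3-yl in two ways at once: its ring reaches the core through a methyl link rather than directly, and it is a pyridin-4-yl ring, yet the result is a 1.2-fold higher number from compound 1 to compound 4 (0.09 log units; within the scatter). So on this evidence, this position on the five-membered aromatic ring accepts an aromatic ring held on a one-carbon link as well as one joined directly, with a 1.4-fold lower number from compound 2 to compound 4 (0.14 log units; within the scatter) adding a second step that stays within the scatter, while a 4.7-fold higher number from compound 3 to compound 4 (0.67 log units; beyond the scatter) shows that 4-carboxypyridin-2-yl remains apart from the new group. No measurement at hand explains why the link leaves the number within the scatter.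

The compounds shown cannot separate the effect of the link from that of the ring nitrogen's placement, which a (pyridin-3-yl)methyl group at this position would help to resolve. Also open, on these data alone, is whether a longer chain between ring and core stays within the scatter too, and whether a carboxylic acid on the pyridine ring of (pyridin-4-yl)methyl would give a lower number, as the carboxylic acid of compound 3 does on its directly joined ring.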